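A Methoxy for Chloro Swap and Cell Toxicity

The source may hold more compounds than are shown below. What is called first, only, known or untested is meant among the compounds shown, and "the series" means these compounds.

Measured so far, in an ADME assay on RD cells (Homo sapiens) for cytotoxicity, read by MTT assay, with a stated time of 3 days; on this read-out higher numbers stand for lower toxicity in this test and lower numbers for higher toxicity in this test:
compound 1, `CC[C@@H](CCn1cncn1)c1ccc(Cl)cc1`, gives 55.3 ug/mL;
compound 2, `CC[C@@H](CCn1cncn1)c1ccc(OC)cc1`, gives 115 ug/mL;
compound 3, `CCCC[C@H](CCn1cncn1)c1ccc(Cl)cc1`, gives 20.3 ug/mL.

Compound 1 and compound 2 differ in one place only, (methoxy in place of chloro on an aromatic carbon), and that change gave a 2.1-fold higher number from compound 1 to compound 2 (0.32 log units; beyond the scatter). Compound 3 shows the lowest of the three numbers in this assay; how its core differs from the core of compound 1 is not broken down here.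

Compound 4, `CCCC[C@H](CCn1cncn1)c1ccc(OC)cc1`, has not yet been measured. Within the data shown here, it differs from compound 3 by methoxy in place of chloro on an aromatic carbon, the same change as the one from compound 1 to compound 2, at the same place. The expectation rests on compound 1 and compound 2, whose step was a 2.1-fold higher number from compound 1 to compound 2 (0.32 log units; beyond the scatter). On that basis the expected step is a 2.1-fold higher number from compound 3 to compound 4 (0.33 log units; beyond the scatter). Compound 4 is therefore expected to give about 43 ug/mL in this assay, most likely between 25 ug/mL and 75 ug/mL.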

Compound 4, half-maximal cytotoxic concentration: 28.3 ug/mL
For compound 4 the middle estimate is 1.5-fold (0.18 log units) above the measured one; measured number inside the range.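

In this assay, the same swap of methoxy in place of chloro on the second core gives a 1.4-fold higher number from compound 3 to compound 4 (0.14 log units; within the scatter). Set side by side, the two steps show no real difference: the same change on two cores in this assay, a 2.1-fold higher number (0.32 log units; beyond the scatter) from compound 1 to compound 2 and a 1.4-fold higher number (0.14 log units; within the scatter) from compound 3 to compound 4, 1.5-fold (0.17 log units) apart, within the scatter of two such steps. So the change carried from the core of compound 1 to the core of compound 3 without a detectable difference in step size, but this does not prove the steps are equal, and two cores cannot set a rule for the whole series.

The compounds shown leave open whether other groups at this place on the ring, such as an amine or a carboxylic acid, would raise or lower the number. They also leave open how the swap would behave with a longer chain on the core.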